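Pyridine isomers on the amide side chain

The compounds below may be only part of what the source reports. "The series", "measured", "known", "first", "only" and "open" are said of these compounds alone.

For the measured compounds named here, in a functional assay on KB cells (Homo sapiens) for antiproliferative activity, read by MTT assay, with a stated time of 72 h, in the presence of a further agent that is not named here (a lower number here means a stronger inhibitor, a higher number a weaker inhibitor), compound 1 (`Nc1nc2[nH]c(CCSCCC(=O)NCc3ccccn3)cc2c(=O)[nH]1`) gives 8930 nM, the lower of the two numbers so far. Going by the values given here, the only other measured compound, compound 2 (`Nc1nc2[nH]c(CCSCCC(=O)NCc3ccncc3)cc2c(=O)[nH]1`), gives 45600 nM. Compound 3 (`Nc1nc2[nH]c(CCSCCC(=O)NCc3cccnc3)cc2c(=O)[nH]1`) has not been measured. Its structural change is pyridin-3-yl in place of pyridin-2-yl on a saturated chain carbon bound to an amide-type nitrogen. Among the compounds with values here, one measured step bears on this, with pyridin-4-yl in place of pyridin-2-yl at the same place: a 5.1-fold higher number from compound 1 to compound 2 (0.71 log units; beyond the scatter). Within the data shown here, that step is modest but beyond the scatter, and it is the only guide available. A step toward a higher number in this assay is therefore expected, similar to that step or smaller. The expected step is a 2.2-fold higher number from compound 1 to compound 3 (0.35 log units; beyond the scatter). For compound 3 the estimated value is 20000 nM, with an expected range of 7000 nM to 55000 nM.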

Compound 3, half-maximal inhibitory concentration: 648 nM
Compound 3: middle estimate off by 31-fold (1.49 log units), on the high side; measured number outside the range, below it.
By their numbers in this assay, from the lowest: compound 3; then compound 1; then compound 2.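

In this assay, pyridin-3-yl in place of pyridin-2-yl on a saturated chain carbon bound to an amide-type nitrogen gives a 14-fold lower number from compound 1 to compound 3 (1.14 log units; beyond the scatter), and pyridin-3-yl in place of pyridin-4-yl at the same place gives a 70-fold lower number from compound 2 to compound 3 (1.85 log units; beyond the scatter). For the compounds shown here, the single earlier step showed only a loss on leaving pyridin-2-yl, whereas these steps show that the outcome at this position depends on the pyridine isomer and can go in either direction, even though the groups exchanged have the same counted atoms, donors and acceptors. Nothing available accounts for this large dependence on the isomer.

The three compounds leave open whether phenylmethyl would retain the level of compound 3, or whether that level depends on the pyridine ring at all. Also open, going by these compounds, is how (pyridin-3-yl)ethyl, a longer chain, would compare with the (pyridin-3-yl)methyl of compound 3.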